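Swapping an octyl chain for a methylphenyl ring

The compounds below may be only part of what the source reports. "The series", "measured", "known", "first", "only" and "open" are said of these compounds alone.

Of the compounds shown here, three have been measured in a functional assay on HeLa cells (Homo sapiens) for inhibition, read by MTT assay, with a stated time of 24 h; on this read-out lower numbers stand for stronger inhibition and higher numbers for weaker inhibition. Compound 1 `CCCCCCCCn1cc(COC2(C(F)(F)F)Oc3ccccc3C=C2C(=O)OCC)nn1` gives > 150000 nM; this is a limit of the assay, not a measured number (the limit of > 150000 nM in this assay, at which 1 of the 3 values shown sits). Compound 2 `CCOC(=O)C1=Cc2ccccc2OC1(OCc1cc(-c2cccc(C(F)(F)F)c2)no1)C(F)(F)F` gives 21400 nM. Compound 3 `CCOC(=O)C1=Cc2ccccc2OC1(OCc1cc(-c2ccc(F)cc2)no1)C(F)(F)F` gives 42300 nM.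

Going by the values given here, the only step between measured compounds that differ in a single place is a 2.0-fold higher number from compound 2 to compound 3 (0.30 log units; within the scatter), so exchanging one substituted phenyl group for another did not move the read-out beyond the scatter in that pair.

Compound 4 `CCOC(=O)C1=Cc2ccccc2OC1(OCc1cn(-c2ccc(C)cc2)nn1)C(F)(F)F` differs from compound 1 by 4-methylphenyl in place of octyl on an aromatic nitrogen. Among the compounds with values here, no measured step tests this particular change. Within the data shown here, compound 2 and compound 3 each carry a substituted phenyl group, as compound 4 does, but they differ from compound 1 in more than one place, so they show only that phenyl-bearing members can return measurable numbers. Compound 1 stands at the limit, so any measurable value for compound 4 would be a lower number. Compound 4 is expected to show a step of an at least 2.1-fold lower number from compound 1 to compound 4 (0.33 log units; beyond the scatter), toward stronger inhibition. Compound 4 is estimated at 70000 nM, with a range from 20000 nM to 200000 nM, and a real chance that only a limit is returned.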

Compound 4, half-maximal inhibitory concentration: 25100 nM
Compound 4: the middle estimate sits 2.8-fold (0.45 log units) above what was measured; low and high end bracket the measured number.
By their numbers in this assay, from the lowest: compounds 2, 4 and 3 (each within the scatter of the next). At a limit, above all of these: compound 1.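

On an aromatic nitrogen of the five-membered aromatic ring, 4-methylphenyl in place of octyl gives an at least 5.9-fold lower number from compound 1 to compound 4 (0.77 log units; beyond the scatter), toward stronger inhibition, and this is the only step shown that lies beyond the scatter, so the read-out does respond to the group at this position. In this assay compound 1 gives > 150000 nM, which is a limit of the assay and not a number. The true size of the step remains unknown because one end of it rests on that limit: the limit of > 150000 nM in this assay, at which 1 of the 4 values shown sits.

This single pair cannot tell whether the change comes from gaining the aromatic ring or from losing the octyl chain, and a butyl chain or an unsubstituted phenyl on the same nitrogen would help separate the two. As far as these compounds go, how an amine or a carboxylic acid on that phenyl ring would read also remains open.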